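The compounds below may be only part of what the source reports. "The series", "measured", "known", "first", "only" and "open" are said of these compounds alone.

Of the compounds shown here, three of one family have been tested in a functional assay on CHO-K1 cells (Cricetulus griseus) for inhibition, read by sulforhodamine B assay, with a stated time of 72 h; on this read-out higher numbers stand for weaker inhibition and lower numbers for stronger inhibition. Compound 1, `COc1cc(/C=C/C(=O)/C=C(/C=C/c2ccc(OC(C)=O)c(OC)c2)NC2CCCCC2)ccc1OC(C)=O`, carries a cyclohexyl group on its amine nitrogen, and its value in this assay is a limit: compound 1 gives > 25000 nM. Compound 3, `CCC(C)NC(=C\C(=O)/C=C/c1ccc(OC(C)=O)c(OC)c1)/C=C/c1ccc(OC(C)=O)c(OC)c1`, has the same core with a sec-butyl group on that nitrogen, and here too only a limit is reported, since compound 3 gives > 25000 nM. The change between them, (cyclohexyl in place of sec-butyl on an amine nitrogen), therefore made a step that the two limits leave unreadable from compound 3 to compound 1; its size is not readable because the limit of > 25000 nM in this assay, at which 2 of the 3 values shown sit, covers both ends of it. Compound 2, `CCC(C)NC(=C\C(=O)/C=C/c1ccc(O)cc1)/C=C/c1ccc(O)cc1`, differs from compound 3 in its core, and that difference between the two cores is not broken down here. Among the measured compounds shown here, compound 2 is the only member with a number rather than a limit: compound 2 gives 15100 nM.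

Compound 4, `O=C(/C=C(/C=C/c1ccc(O)cc1)NC1CCCCC1)/C=C/c1ccc(O)cc1`, is not yet measured. It relates to compound 2 as compound 1 relates to compound 3, through (cyclohexyl in place of sec-butyl on an amine nitrogen), the same kind of change on the same kind of place. Since the earlier example of this change left no readable size, the expectation for compound 4 rests mainly on compound 2 giving 15100 nM and on the change being expected to matter little. The step from compound 2 to compound 4 is thus estimated at a 1.0-fold lower number from compound 2 to compound 4 (0.00 log units; within the scatter). For compound 4 the expected value is 15000 nM, with a plausible range from 5000 nM to 30000 nM.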

Compound 4, half-maximal inhibitory concentration: 11600 nM
For compound 4 the middle estimate is 1.3-fold (0.11 log units) above the measured one, within the range that was stated.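

In this assay, cyclohexyl in place of sec-butyl on the amine nitrogen gives a 1.3-fold lower number from compound 2 to compound 4 (0.11 log units; within the scatter), so on this core the two groups cannot be told apart by this read-out. The same change on the other core, where it leads from compound 3 to compound 1, has no size that can be read, because both compounds sit at a limit of the assay rather than at a number: the limit of > 25000 nM in this assay, at which 2 of the 4 values shown sit. Among the compounds shown here, the series therefore offers only one readable example of this change, which suggests that the swap makes little difference on one core but does not show that this result carries over to the core of compound 3.

The compounds shown leave open how other groups on the amine nitrogen would read in this assay, for example a small methyl, a benzyl group with its aromatic ring, or a longer chain ending in a carboxylic acid or an amine. They also leave open which part of the difference between the two cores matters, since a core carrying the methoxy group alone or the acetyl ester alone would be needed to separate the two.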